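A few compounds are considered here, and "the series" means these few. Any claim that something is new, unique, unknown or untested is made for them only; others in the source may bear on it.

Measured so far:
compound 1 `CCCc1c(OC)nc2nc(C(=O)c3ccccc3)cn2c1CC`, 10 mg/kg;
compound 2 `CCc1c(OC)nc2nc(C(=O)c3ccccc3)cn2c1CC`, 2 mg/kg;
compound 3 `CCCCc1cc(OC)nc2nc(C(=O)c3ccccc3)cn12`, 10 mg/kg.

All three were tested in a functional assay on the whole organism with Rattus norvegicus as the target; on this read-out lower numbers stand for an effect already at smaller amounts and higher numbers for an effect only at larger amounts of compound. Compound 1 and compound 3 stand level at the digits given, and together they carry the highest numbers of the three. Going by the values given here, the one change that has been measured is the trimming of a chain: hydrogen in place of methyl on a saturated chain carbon, two bonds along the chain from an aromatic carbon. It brought a 5.0-fold lower number from compound 1 to compound 2 (0.70 log units; beyond the scatter), a modest step that still lies beyond the usual scatter.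

Compound 4 `CCCc1cc(OC)nc2nc(C(=O)c3ccccc3)cn12` has not been measured. It differs from compound 3 by hydrogen in place of methyl on a saturated chain carbon, three bonds along the chain from an aromatic carbon. Among the compounds with values here, this is the same kind of change as the one from compound 1 to compound 2, though not the same: there the carbon that loses its methyl sits two bonds along the chain from an aromatic carbon, here it sits three bonds along. The difference between the core of compound 3 and the core of compound 1 is not broken down here.

Resting on a single measured example, the expectation for compound 4 in this assay is a step of about a 2.5-fold lower number from compound 3 to compound 4 (0.40 log units; beyond the scatter), somewhat smaller than the measured one because a 5.0-fold lower number from compound 1 to compound 2 (0.70 log units; beyond the scatter) came from a carbon two bonds along the chain from an aromatic carbon, whereas here the carbon sits three bonds along. Compound 4 is expected to give roughly 4 mg/kg, within 1.5 mg/kg to 15 mg/kg.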

Compound 4, minimum effective dose: 1 mg/kg
The estimate for compound 4 lay 4.0-fold (0.60 log units) above the measured number; the whole stated range lies above it.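

In this assay hydrogen in place of methyl on the chain of compound 3 gave a 10-fold lower number from compound 3 to compound 4 (1.00 log units; beyond the scatter) and so went the same way as the earlier step on the other core. This supports carrying the change between these two cores, even though the carbon that loses its methyl sits at a different distance along the chain in each pair, but two pairs cannot show that it would hold on any further core, and they do not explain why the number falls. The two results can be treated as one trend, with no measurable difference between the cores: the same change on two cores in this assay, a 5.0-fold lower number (0.70 log units; beyond the scatter) from compound 1 to compound 2 and a 10-fold lower number (1.00 log units; beyond the scatter) from compound 3 to compound 4, 2.0-fold (0.30 log units) apart, within the scatter of two such steps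

From the compounds shown here alone, whether trimming further, from propyl to ethyl or from ethyl to methyl on the core of compound 3, keeps lowering the number remains open. So does the effect of a longer chain, or of a chain carrying an amine or a carboxylic acid, in this assay on either core.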